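The source may hold more compounds than are shown below. What is called first, only, known or untested is meant among the compounds shown, and "the series" means these compounds.

Within the data shown here, in a functional assay on MDA-MB-231 cells (Homo sapiens) for inhibition, read by MTT assay, with a stated time of 48 h (a higher number here means a weaker inhibitor, a lower number a stronger inhibitor), no compound tested so far has given a number. Compound 1 `CCn1c(/C=C2\SC(=O)N(CC(=O)N3CCCCC3)C2=O)nc2ccccc21` reads > 50000 nM, which is a limit of the assay and not a number. Compound 2 `Cn1c(/C=C2\SC(=O)N(CC(=O)N3CCOCC3)C2=O)nc2ccccc21` reads > 50000 nM, again a limit. Compound 3 `CC(C)n1c(/C=C2\SC(=O)N(CC(=O)N3CCOCC3)C2=O)nc2ccccc21` reads > 50000 nM, also a limit, so it has no exact position on the scale. Among the measured compounds shown here, the series so far comes down to one reading: the limit of > 50000 nM in this assay, at which 3 of the 3 values shown sit.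

Compound 4 `CC(C)n1c(/C=C2\SC(=O)N(CC(=O)N3CCCCC3)C2=O)nc2ccccc21` changes one group of compound 3: piperidin-1-yl in place of morpholin-4-yl on a carbonyl carbon. For the measured compounds named here, the only measured step is a step that the two limits leave unreadable from compound 2 to compound 3, and it concerns a different place, so it offers no size to carry over. Compound 1 already carries piperidin-1-yl on a carbonyl carbon and gave no number in this assay. No step beyond the usual scatter is therefore expected, in either direction. The estimated step is a number no higher from compound 3 to compound 4 (the limit leaves the size open). For compound 4 the estimate is 50000 nM, with an expected range from 25000 nM to 100000 nM, and the likeliest outcome is another limit.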

Compound 4, half-maximal inhibitory concentration: > 50000 nM
Compound 4: only a limit was reported; the forecaster's own chance of this, stated with the estimate: 80%; the middle value sits exactly at the limit.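

In this assay compound 4 gives > 50000 nM, a limit and not a number. The steps to compound 4 from compound 3 and from compound 1 therefore cannot be read: the limit of > 50000 nM in this assay, at which 4 of the 4 values shown sit.

The compounds shown leave open whether any of these group changes alters activity, and what would give a measurable number.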